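The source may report more compounds than this note shows. Statements on the series, on what has been measured and on what is new or still open speak of the compounds shown alone.

Compound 2 `Cc1noc(-c2c(F)cccc2-c2ccc([C@@H](C)Nc3nccc(Cl)c3NC(=O)CC#N)cc2)n1` is the reference for this step; in an in vivo ADME assay on the whole organism (strain Sprague-Dawley) for pharmacokinetics, with Rattus norvegicus as the target, at a dose of 10 mg/kg by the oral route (on this read-out higher numbers stand for higher oral bioavailability and lower numbers for lower oral bioavailability), compound 2 gives 62%. Among the measured compounds shown here, the only other number is that of compound 1 `C[C@@H](Nc1nccc(Cl)c1NC(=O)CC#N)c1ccc(-c2cccc(F)c2C(F)(F)F)cc1`, which in this assay gives 52%, within the scatter of compound 2. For the measured compounds named here, the single measured step, a number 10 percentage points higher from compound 1 to compound 2 (within the scatter), is the one that bears here, as it also exchanged one ring for another on the same carbon. Compound 3 `C[C@@H](Nc1nccc(Cl)c1NC(=O)CC#N)c1ccc(-c2cccc(F)c2-c2nnn(C)n2)cc1` differs from compound 2 by 2-methyl-2H-tetrazol-5-yl in place of 3-methyl-1,2,4-oxadiazol-5-yl on an aromatic carbon. A shift of similar size, none beyond the scatter, is expected, a number 4 percentage points lower from compound 2 to compound 3 (within the scatter). Compound 3 is estimated at 58%, between 40% and 75%.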

Compound 3, oral bioavailability: 73%
Beside the measured number, compound 3's estimate is 15 percentage points below it, and the stated range covers the measured number.
By their numbers in this assay, from the lowest: compounds 1 and 2 (each within the scatter of the next); then compound 3.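

Among the compounds shown here, at this position, on an aromatic carbon ortho to a fluoro group, the 2-methyl-2H-tetrazol-5-yl gives the only steps beyond the scatter in this assay: a number 11 percentage points higher from compound 2 to compound 3 (beyond the scatter), and a number 21 percentage points higher from compound 1 to compound 3 (beyond the scatter). Two five-membered aromatic rings are thus told apart here, which the exchange of trifluoromethyl for 3-methyl-1,2,4-oxadiazol-5-yl did not show for its two groups. No measurement at hand accounts for the difference.

Open, on these data alone, is whether the gain holds for 2-ethyl-2H-tetrazol-5-yl, 1H-tetrazol-5-yl or a carboxylic acid on this carbon.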